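Cytotoxicity notes: acetylthiophene for naphthyl in the ester series

This account rests on a few compounds, and the source may have more. Where it says the series, first, only, none or still open, it means among the compounds named here.

Compound 3 `CCOC(=O)CCCCCOc1cccc(CN(C(=O)c2ccc(-c3cccc4ccccc34)cc2)C(C)C)c1` stands at the limit of an ADME assay on Raji cells (Homo sapiens) for cytotoxicity, read by CellTiter-Glo and resazurin assay, with a stated time of 72 h; on this read-out lower numbers stand for an effect already at smaller amounts and higher numbers for an effect only at larger amounts of compound: in this assay compound 3 gives only a limit, > 26000 nM, not a number. Compound 1 `CC(C)N(Cc1cccc(OCCCCCC(=O)O)c1)C(=O)c1ccc(-c2cccc3ccccc23)cc1` is in the same position; in this assay compound 1 gives the limit > 26000 nM. Compound 2 `CC(C)N(Cc1cccc(OCCCCCC(=O)O)c1)C(=O)c1ccc(-c2ccc3[nH]ccc3c2)cc1` likewise; in this assay compound 2 gives the limit > 26000 nM. The two steps that connect these three compounds are therefore unreadable: a step that the two limits leave unreadable from compound 1 to compound 2, and a step that the two limits leave unreadable from compound 1 to compound 3. All that the three values show is the limit of > 26000 nM in this assay, at which 3 of the 3 values shown sit.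

Compound 4 `CCOC(=O)CCCCCOc1cccc(CN(C(=O)c2ccc(-c3ccc(C(C)=O)s3)cc2)C(C)C)c1` differs from compound 3 in one place: 5-acetylthiophen-2-yl in place of naphthalen-1-yl on an aromatic carbon. Going by the values given here, no measured step in this assay has a readable size, so none bears on this change with a direction or a magnitude. The only expectation that the series supports is that compound 4 will sit where compound 3 sits, at the limit, with the estimated step of a number no higher from compound 3 to compound 4 (the limit leaves the size open) being no more than the scatter. Compound 4 is estimated to give about 26000 nM in this assay, within a range from 9000 nM to 60000 nM, most probably reported as a limit rather than a number.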

Compound 4, half-maximal effective concentration: > 26000 nM
Compound 4 ended at the assay's limit (the forecaster's own chance of this, stated with the estimate: 75%); the middle value sits exactly at the limit.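

No new step can be read between compound 3 and compound 4, as both stand at a limit and not at a number: the limit of > 26000 nM in this assay, at which 4 of the 4 values shown sit. Left open is whether 5-acetylthiophen-2-yl, naphthalen-1-yl or 1H-indol-5-yl, or the ethyl ester against the free acid, makes any difference in this assay, and at what concentration any of these compounds would show an effect.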